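This account rests on a few compounds, and the source may have more. Where it says the series, first, only, none or still open, it means among the compounds named here.

Two measured members of the series set the frame. Compound 1 `O=C(/C(=C\c1ccc(F)cc1Cl)Sc1ccc(Br)cc1)c1ccc(Br)cc1` in a functional assay on DU-145 cells (Homo sapiens) for inhibition, read by trypan blue exclusion, with a stated time of 96 h (a higher number here means a weaker inhibitor of growth, a lower number a stronger inhibitor of growth), gives 1000 nM. Compound 2 `Cc1ccc(CS/C(=C/c2cc(Cl)cc(Cl)c2)C(=O)c2ccc(Cl)cc2)cc1` in this assay gives 10000 nM, the higher of the two numbers, and its gap from compound 1 lies beyond the scatter, so compound 2 is the weaker growth inhibitor of the pair.

Compound 3 `Cc1ccc(CS/C(=C/c2c[nH]c3ccc(Br)cc23)C(=O)c2ccc(Cl)cc2)cc1` is not yet measured. It differs from compound 2 in one place: 5-bromo-1H-indol-3-yl in place of 3,5-dichlorophenyl on a double-bonded chain carbon bound to a double-bonded chain carbon. For the measured compounds named here, no measured pair shows this change, so its effect cannot be read from a step; the expectation rests only on compound 2 and on the size of the change, which adds a hydrogen-bond donor and a second ring.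

The step from compound 2 to compound 3 is expected to be a moderate one toward a lower number, a 2.5-fold lower number from compound 2 to compound 3 (0.40 log units; beyond the scatter), with wide uncertainty. Compound 3 in this assay is therefore estimated at 4000 nM, within 800 nM to 20000 nM.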

Compound 3, concentration for 50% growth inhibition: 1000 nM
Compound 3: middle estimate off by 4.0-fold (0.60 log units), on the high side; the measured number falls inside the stated range.
By their numbers in this assay, from the lowest: compounds 1 and 3 (each within the scatter of the next); then compound 2.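

In this assay, 5-bromo-1H-indol-3-yl in place of 3,5-dichlorophenyl on a double-bonded chain carbon bound to a double-bonded chain carbon gives a 10-fold lower number from compound 2 to compound 3 (1.00 log units; beyond the scatter), which shows that the group at this position can shift the growth-inhibition read-out beyond the scatter. The change brings in a second ring, a hydrogen-bond donor and bromine in a single swap, and loses both chlorines, so the step belongs to the whole group and cannot be divided among these parts. No measurement at hand gives a cause for this step.

Open, from the compounds shown here alone, is whether the bromine matters or the two rings alone carry the step; an unsubstituted 1H-indol-3-yl, or a methoxy group in place of the bromine, would separate these. Also open, going by these compounds, is whether the same change keeps its size on the core of compound 1.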